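Adding a second chloro to the cinnamamide aryl ring

The source may report more compounds than this note shows. Statements on the series, on what has been measured and on what is new or still open speak of the compounds shown alone.

Measured so far:
- compound 1 `CCCc1cc(N)c2cc(NC(=O)/C=C/c3ccc(Br)cc3)ccc2n1` — 4 nM
- compound 2 `CCCc1cc(N)c2cc(NC(=O)/C=C/c3ccccc3Cl)ccc2n1` — 120 nM
- compound 3 `Nc1cc(-c2ccccc2)nc2ccc(NC(=O)/C=C/c3ccc(C(F)(F)F)cc3)cc12` — 18.5 nM

In an assay on isolated protein for displacement of a labelled ligand from melanin-concentrating hormone receptor 1 (Homo sapiens) (on this read-out lower numbers stand for stronger inhibition and higher numbers for weaker inhibition), compound 1 gives 4 nM, compound 3 gives 18.5 nM and compound 2 gives 120 nM. Compound 2 thus stands highest of the three numbers on this read-out, with its steps to both other compounds beyond the scatter.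

The next compound, compound 4 `CCCc1cc(N)c2cc(NC(=O)/C=C/c3ccc(Cl)cc3Cl)ccc2n1`, differs from compound 2 by chloro in place of hydrogen on an aromatic carbon. Among the measured compounds shown here, only one measured step bears on this change: a 30-fold higher number from compound 1 to compound 2 (1.48 log units; beyond the scatter), where a halogen moved from the 4-position to the 2-position of the aryl ring. Compound 4 keeps the 2-chloro of compound 2 and puts a halogen back at the 4-position, as in compound 1. Compound 3, which also carries a group at the 4-position, sits well below compound 2 as well.

The expectation is therefore a lower number for compound 4, though probably not all the way back to compound 1, since the 2-chloro remains: the estimated step is an 8.0-fold lower number from compound 2 to compound 4 (0.90 log units; beyond the scatter). Compound 4 is estimated at 15 nM, in a range from 4 nM to 60 nM.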

Compound 4, half-maximal inhibitory concentration: 6.6 nM
Beside the measured number, compound 4's estimate is 2.3-fold (0.36 log units) above it, and the stated range covers the measured number.
By their numbers in this assay, from the lowest: compounds 1 and 4 (each within the scatter of the next); then compound 3; then compound 2.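

In this assay, chloro in place of hydrogen, para to a large group and meta to the chloro already present, gives an 18-fold lower number from compound 2 to compound 4 (1.26 log units; beyond the scatter) and so marks this aromatic carbon as a place where one added atom moves the number a long way. Among the compounds shown here, the earlier compounds showed only that the 2-chlorophenyl of compound 2 stood well above the 4-bromophenyl of compound 1, which left it unclear whether the 2-chloro alone set the high number. The 2,4-dichlorophenyl answers this, as the 2-chloro stays in place while a 1.7-fold higher number from compound 1 to compound 4 (0.22 log units; within the scatter) leaves the two compounds within the scatter of each other, and no measurement shown gives a reason for the size of the step.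

Going by these compounds, what the 4-chloro contributes without the 2-chloro remains open, so the share of the 2-chloro in compound 4 cannot be separated out. Also open, on these data alone, is how a methoxy group, an amine or a carboxylic acid would read at this same aromatic carbon, and how the 2,4-dichlorophenyl would read on the core of compound 3.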